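The compounds below may be only part of what the source reports. "The series", "measured", "known", "first", "only" and "open" are said of these compounds alone.

Working notes on the series. Compound 1 `COc1cc2c(cc1OC)C(c1ccc([N+](=O)[O-])cc1)=NN=C(S)C2` and compound 2 `COc1cc2c(cc1OC)C(c1ccc(Cl)cc1)=NN=C(S)C2` share one core; compound 3 `COc1cc2c(cc1OC)C(c1ccc([N+](=O)[O-])cc1)=NNC(=O)C2` and compound 4 `COc1cc2c(cc1OC)C(c1ccc(Cl)cc1)=NNC(=O)C2` share another, and the difference between the two cores is not broken down here. In a functional assay on the whole organism with Mus musculus as the target (on this read-out higher numbers stand for an effect only at larger amounts of compound and lower numbers for an effect already at smaller amounts), compound 1 gives 69.8 umol/kg. In this assay compound 2 gives 55 umol/kg. The change chloro in place of nitro on an aromatic carbon thus produced a 1.3-fold lower number from compound 1 to compound 2 (0.10 log units; within the scatter). For compound 3 this assay reports only a limit, > 120 umol/kg; see (the limit of > 120 umol/kg in this assay, at which 1 of the 3 values shown sits). Compound 4 differs from compound 3 by chloro in place of nitro on an aromatic carbon, the same change in the same place. For compound 4 the expected step is a step that the limit leaves unreadable from compound 3 to compound 4, a small one, because the same change gave a 1.3-fold lower number from compound 1 to compound 2 (0.10 log units; within the scatter). Compound 4 is therefore estimated at 150 umol/kg, with a range from 70 umol/kg to 320 umol/kg, and a limit rather than a number is the likelier report.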

Compound 4, dose for half-maximal effect: 75.3 umol/kg
Estimate against measurement, compound 4: 2.0-fold (0.30 log units) above; low and high end bracket the measured number.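

Chloro in place of nitro on an aromatic carbon gives, in this assay, an at least 1.5-fold lower number from compound 3 to compound 4 (0.20 log units; that floor lies within the scatter). Set beside the same change on the other core, this fits with the change carrying across the two cores, but it does not show that the step has the same size on both: the same change on two cores in this assay, a 1.3-fold lower number (0.10 log units; within the scatter) from compound 1 to compound 2 and an at least 1.5-fold lower number (0.20 log units; that floor lies within the scatter) from compound 3 to compound 4; the limit leaves it open whether they differ. For compound 3 the value > 120 umol/kg is a limit and not a number, so the size of the step on this core stays unread, and two cores support no general rule.

The compounds shown leave open how an amine or a carboxylic acid on that aromatic carbon would read in this assay. Also open, from the compounds shown here alone, is what a longer chain in place of the methoxy groups would do.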